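The compounds below may be only part of what the source reports. "The series", "measured", "known", "first", "only" and "open" are said of these compounds alone.

Measured in an ADME assay on L6 cells (Rattus norvegicus) for cytotoxicity; on this read-out lower numbers stand for stronger inhibition and higher numbers for weaker inhibition:
- compound 1 `CCN(CC)CC(=O)OC1CC2(N3CCCCC3)CC(c3ccccc3)C1C(c1ccccc1)C2`: 23900 nM; 61300 nM (2 entries)
- compound 2 `CCN(CC)CCC(=O)OC1CC2(N3CCCC3)CC(c3ccccc3)C1C(c1ccccc1)C2`: 19200 nM
- compound 3 `CCN(CC)CCC(=O)OC1CC2(N3CCCCC3)CC(c3ccccc3)C1C(c1ccccc1)C2`: 22900 nM

Compound 3 stands within the scatter of compound 2, and compound 1 offers no single number for comparison. Next is compound 4 `O=C(CCN1CCCC1)OC1CC2(N3CCCCC3)CC(c3ccccc3)C1C(c1ccccc1)C2`, with pyrrolidin-1-yl in place of diethylamino on a saturated chain carbon, two bonds along the chain from a carbonyl carbon.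

The closest measured step is a 1.2-fold higher number from compound 2 to compound 3 (0.08 log units; within the scatter), a swap of piperidin-1-yl for pyrrolidin-1-yl on a saturated ring carbon, so at another place. It stays within the scatter, so no step beyond the scatter is expected in this assay. The estimated step is a 1.0-fold higher number from compound 3 to compound 4 (0.02 log units; within the scatter). The range is kept wide because of the several entries of compound 1 in this assay, 23900 nM; 61300 nM (2 entries). The estimate for compound 4 is 24000 nM, with an expected range of 11000 nM to 55000 nM.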

Compound 4, half-maximal inhibitory concentration: 12500 nM
Estimate against measurement, compound 4: 1.9-fold (0.28 log units) above; measured number inside the range.
By their numbers in this assay, from the lowest: compounds 4, 2 and 3 (each within the scatter of the next).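

In this assay, replacing diethylamino with pyrrolidin-1-yl on the chain gives a 1.8-fold lower number from compound 3 to compound 4 (0.26 log units; within the scatter), so this chain position, like the saturated ring carbon, shows no step beyond the scatter on a change of amine. Heavy-atom counts match between the leaving and entering groups, so this pair compares only an open amine with a ring. Entries for a single compound can also lie far apart: the several entries of compound 1 in this assay, 23900 nM; 61300 nM (2 entries).

Open, as far as these compounds go, is whether morpholin-4-yl or a primary amine at this place, or a longer chain before the amine, would give a step beyond the scatter.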